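A few compounds are considered here, and "the series" means these few. Any claim that something is new, unique, unknown or untested is made for them only; others in the source may bear on it.

Compound 1 `CC(=O)N[C@@H](CSC(=S)Nc1cccc(NC(=S)SC[C@H](NC(C)=O)C(=O)O)c1)C(=O)O`: in a functional assay on LoVo cells (Homo sapiens) for antiproliferative activity, read by sulforhodamine B assay, with a stated time of 72 h (on this read-out lower numbers stand for stronger inhibition and higher numbers for weaker inhibition), compound 1 gives only a limit, > 25000 nM.
Compound 2 `CC(=O)N[C@@H](CSC(=S)Nc1ccc(C)c(NC(=S)SC[C@H](NC(C)=O)C(=O)O)c1)C(=O)O`: in this assay compound 2 gives 20500 nM.
Compound 3 `S=C=Nc1cccc(N=C=S)c1`: in this assay compound 3 gives 46400 nM.

From compound 1 to compound 2 the change is methyl in place of hydrogen on an aromatic carbon, and it gave an at least 1.2-fold lower number from compound 1 to compound 2 (0.08 log units; that floor lies within the scatter); the floor of that step rests on (the limit of > 25000 nM in this assay, at which 1 of the 3 values shown sits). Compound 4 `Cc1ccc(N=C=S)cc1N=C=S` stands to compound 3 as compound 2 stands to compound 1: the change is methyl in place of hydrogen on an aromatic carbon. The surroundings of the place are not described in the same words, one being ortho and para to a large group and the other ortho and para to a group of 3 heavy atoms, so this is the same kind of change rather than the same change. The difference between the core of compound 1 and the core of compound 3 is not broken down here. In this assay a small lowering is expected for compound 4, a 1.5-fold lower number from compound 3 to compound 4 (0.16 log units; within the scatter), resting on an at least 1.2-fold lower number from compound 1 to compound 2 (0.08 log units; that floor lies within the scatter). Compound 4 is thus estimated at 32000 nM, expected to lie between 15000 nM and 65000 nM.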

Compound 4, half-maximal inhibitory concentration: 35200 nM
The estimate for compound 4 lay 1.1-fold (0.04 log units) below the measured number; the measured number falls inside the stated range.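

In this assay, methyl in place of hydrogen on an aromatic carbon gives a 1.3-fold lower number from compound 3 to compound 4 (0.12 log units; within the scatter), so on the core of compound 3 the change has no effect that stands clear of the scatter. Set beside the earlier step, this is compatible with the change carrying over from one core to the other: the same change on two cores in this assay, an at least 1.2-fold lower number (0.08 log units; that floor lies within the scatter) from compound 1 to compound 2 and a 1.3-fold lower number (0.12 log units; within the scatter) from compound 3 to compound 4; the limit leaves it open whether they differ. It does not show that the step has the same size on both cores, since the earlier step is only a floor that rests on a limit: the limit of > 25000 nM in this assay, at which 1 of the 4 values shown sits.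

The compounds shown leave open whether an amine, a carboxylic acid or a longer chain such as ethyl on that aromatic carbon would move the number beyond the scatter on either core. They also leave open how methyl would behave on another aromatic carbon of the ring.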